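Mirror-image pair in a cell toxicity test

The compounds below may be only part of what the source reports. "The series", "measured", "known", "first", "only" and "open" are said of these compounds alone.

Measured compounds:
compound 1, `CC[C@@H](CCn1cncn1)c1ccc(C)cc1`: 79.4 ug/mL
compound 2, `CCC[C@@H](CCn1cncn1)c1ccc(Cl)cc1`: 40.8 ug/mL
compound 3, `CCC[C@H](CCn1cncn1)c1ccc(C)cc1`: 47.2 ug/mL

These three were tested in an ADME assay on RD cells (Homo sapiens) for cytotoxicity, read by MTT assay, with a stated time of 3 days; on this read-out higher numbers stand for lower toxicity in this test and lower numbers for higher toxicity in this test. Compound 3 gives a number close to those of compound 2 and compound 1, and both gaps lie within the usual scatter, so the three cannot be told apart on this read-out.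

The next compound is compound 4, `CCC[C@@H](CCn1cncn1)c1ccc(C)cc1`. Going from compound 3 to compound 4, (the two compounds have the same atoms and bonds and differ only in configuration as drawn: 1 of 1 stereo elements differ; a stereocentre at a saturated chain carbon is drawn R in compound 3 and S in compound 4). Among the compounds with values here, no measured pair in this set shows what such a change does in this assay. Since the atoms and bonds stay the same, the step from compound 3 to compound 4 is expected to be none beyond the scatter, as shown by a 1.0-fold lower number from compound 3 to compound 4 (0.00 log units; within the scatter). Compound 4 is therefore expected to give about 47 ug/mL, within a range of 25 ug/mL to 90 ug/mL.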

Compound 4, half-maximal cytotoxic concentration: 74.1 ug/mL
The estimate for compound 4 lay 1.6-fold (0.20 log units) below the measured number, and the stated range covers the measured number.
By their numbers in this assay, from the lowest: compounds 2, 3, 4 and 1 (each within the scatter of the next).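

In this assay, the two mirror-image forms cannot be told apart, with a 1.6-fold higher number from compound 3 to compound 4 (0.20 log units; within the scatter), and the comparison isolates configuration alone: the fact that compounds 3 and 4 differ only in the configuration as drawn Methyl in place of chloro on an aromatic carbon gives a 1.8-fold higher number from compound 2 to compound 4 (0.26 log units; within the scatter), and methyl in place of hydrogen on a saturated chain carbon, three bonds along the chain from an aromatic carbon, gives a 1.1-fold lower number from compound 1 to compound 4 (0.03 log units; within the scatter), so neither of these changes separates its pair on this read-out either.

Still open, on these data alone, is whether an amine or a carboxylic acid on that aromatic carbon, or a longer chain on the saturated carbon, would move the number beyond the scatter.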